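Three Inactive Amides and a New Indole Variant

This account rests on a few compounds, and the source may have more. Where it says the series, first, only, none or still open, it means among the compounds named here.

Compound 1 `CCCn1c(NC(=O)c2ccccn2)nc2cc(C(N)=O)cc(OC)c21`: in an assay for activation of interferon regulatory factor 3 (Homo sapiens), read by a luciferase reporter, with a stated time of 20 h (on this read-out higher numbers stand for an effect only at larger amounts of compound and lower numbers for an effect already at smaller amounts), compound 1 gives > 100000 nM, a limit of the assay.
Compound 2 `CCCn1c(NC(=O)c2ccnn2CC)nc2cc(C(N)=O)cc(OC)c21`: in this assay compound 2 gives > 100000 nM, again a limit.
Compound 3 `COc1cc(C(N)=O)cc2nc(NC(=O)c3ccccn3)n(CCCNC(=O)OCc3ccccc3)c12`: in this assay compound 3 gives > 100000 nM, also a limit.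

Compound 3 therefore stands at the same limit as the two other measured compounds; no number is known for any of them, and the limit of > 100000 nM in this assay, at which 3 of the 3 values shown sit, is the whole of the evidence. The step that the two limits leave unreadable from compound 1 to compound 2 and the step that the two limits leave unreadable from compound 1 to compound 3 cannot be sized for the same reason.

Compound 4 `COc1cc(C(N)=O)cc2nc(NC(=O)c3cc4ccccc4n3C)n(CCCNC(=O)OCc3ccccc3)c12` differs from compound 3 in one place: 1-methyl-1H-indol-2-yl in place of pyridin-2-yl on a carbonyl carbon. Within the data shown here, no measured step touches this exchange, so neither its direction nor its size can be anticipated from the record. Among the measured compounds shown here, the only guidance is that every compound so far sits at the limit, which makes a further limit the more probable outcome, while leaving open that the larger aromatic group could bring the value into the measurable range.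

Compound 4 is accordingly estimated at 80000 nM, with a range from 5000 nM to 300000 nM. The step of an at least 1.2-fold lower number from compound 3 to compound 4 (0.09 log units; that floor lies within the scatter) that this estimate means is expected to lie within the uncertainty rather than to mark a clear change.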

Compound 4, half-maximal effective concentration: > 100000 nM
Compound 4 gave a limit, no number; the forecaster's own chance of this, stated with the estimate: 70%; middle value at least 1.2-fold (0.09 log units) away from the limit.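

Compound 3 and compound 4 both sit at a limit in this assay, so no step can be read between them. The compounds shown leave open whether any amide on the shared core gives a measurable value, as all that is known is this: the limit of > 100000 nM in this assay, at which 4 of the 4 values shown sit.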